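A few compounds are considered here, and "the series" means these few. Any claim that something is new, unique, unknown or untested is made for them only; others in the source may bear on it.

Measured so far:
Compound 1, `Nc1ccccc1-c1cnc(C(=O)CCCCCCc2ccccc2)o1`, gives 750 nM in an assay (Rattus norvegicus) for inhibition of Fatty-acid amide hydrolase 1 (Homo sapiens); on this read-out lower numbers stand for stronger inhibition and higher numbers for weaker inhibition.
Compound 2, `N#Cc1cccc(-c2cnc(C(=O)CCCCCCc3ccccc3)o2)c1`, gives 15 nM in this assay.
Compound 3, `Cc1ccnc(-c2cnc(C(=O)CCCCCCc3ccccc3)o2)c1`, gives 0.6 nM in this assay.

Compound 3 has the lowest number of the three, and both of its gaps to the others are beyond the scatter: a 1300-fold lower number from compound 1 to compound 3 (3.10 log units; beyond the scatter) and a 25-fold lower number from compound 2 to compound 3 (1.40 log units; beyond the scatter). The three compounds share one core and differ only in the aromatic group attached to it.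

Compound 4, `O=C(CCCCCCc1ccccc1)c1ncc(-c2ncccn2)o1`, continues this series: pyrimidin-2-yl in place of 4-methylpyridin-2-yl on an aromatic carbon. Within the data shown here, no measured step involves a pyrimidin-2-yl group, so the three recorded steps offer only indirect guidance. They show that changing this aromatic group can move the number a great deal, as in a 50-fold lower number from compound 1 to compound 2 (1.70 log units; beyond the scatter). The new group keeps a ring nitrogen, as in compound 3, but loses the methyl and gains a second ring nitrogen.

For compound 4 a step of a 5.0-fold higher number from compound 3 to compound 4 (0.70 log units; beyond the scatter) in this assay is expected, toward a somewhat higher number, with the direction uncertain. The expected value for compound 4 is 3 nM, between 0.6 nM and 15 nM.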

Compound 4, inhibition constant: 5.3 nM
Estimate against measurement, compound 4: 1.8-fold (0.25 log units) below; the range from low to high includes it.
By their numbers in this assay, from the lowest: compound 3; then compound 4; then compound 2; then compound 1.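

In this assay, the step of an 8.8-fold higher number from compound 3 to compound 4 (0.95 log units; beyond the scatter) shows that this position still responds when one ring bearing a ring nitrogen replaces another, although the change is smaller than the swaps away from 2-aminophenyl. Compound 4 also keeps a clear lead over both compounds with a phenyl ring at this position, with a 2.8-fold lower number from compound 2 to compound 4 (0.45 log units; beyond the scatter) and a 140-fold lower number from compound 1 to compound 4 (2.15 log units; beyond the scatter), so among these four compounds the two with a ring nitrogen give the lowest numbers, and none goes against this. Nothing measured here explains these differences.

Going by these compounds, since the methyl leaves and a second ring nitrogen enters in the same step, the share of each remains open. A plain pyridin-2-yl group or a 4-methylpyrimidin-2-yl group at this position would separate the two.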